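Oxazole for Pyrazole on a Shared Core

The compounds below may be only part of what the source reports. "The series", "measured", "known", "first", "only" and "open" are said of these compounds alone.

compound 1, `Cn1nccc1-c1cccc2c1CCC2c1ncc[nH]1`: > 10000 nM
compound 2, `CCS(=O)(=O)Nc1cccc(Cc2c[nH]cn2)c1`: > 10000 nM
compound 3, `CS(=O)(=O)Nc1cccc2c1CCCC2c1ncc[nH]1`: > 10000 nM; > 10000 nM; > 10000 nM (3 entries)

Going by the values given here, all three compounds measured so far were read in a functional assay on CHO cells for agonist activity at Alpha-1D adrenergic receptor (Homo sapiens), read by FLIPR and calcium flux; on this read-out lower numbers stand for an effect already at smaller amounts and higher numbers for an effect only at larger amounts of compound. Compound 1 gives there only > 10000 nM, which is a limit of the assay and not a number. Compound 2 likewise stops at > 10000 nM, again a limit. Compound 3, tested three times, returns > 10000 nM; > 10000 nM; > 10000 nM (3 entries) on every occasion, a limit each time. So compound 1 stands nowhere in particular on the shown numbers: every entry is a limit, and the limit of > 10000 nM in this assay, at which 2 of the 3 values shown sit, marks where two of the three values sit. Among the compounds with values here, no step between two measured compounds can be computed, and no size of change has been observed.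

Compound 4, `c1cc(-c2ncco2)c2c(c1)C(c1ncc[nH]1)CC2`, is obtained from compound 1 by the change (1,3-oxazol-2-yl in place of 1-methyl-1H-pyrazol-5-yl on an aromatic carbon), that is, 1,3-oxazol-2-yl in place of 1-methyl-1H-pyrazol-5-yl on an aromatic carbon. With only limits on hand, no step beyond the scatter can be predicted in either direction; the expectation is that compound 4 again sits near the same limit. For compound 4 the estimated value in this assay is 20000 nM, within the range 5000 nM to 100000 nM. The expected step that the limit leaves unreadable from compound 1 to compound 4 is therefore essentially none.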

Compound 4, half-maximal effective concentration: 1390 nM
The estimate for compound 4 lay 14-fold (1.16 log units) above the measured number; measured number outside the range, below it.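

In this assay, replacing 1-methyl-1H-pyrazol-5-yl with 1,3-oxazol-2-yl on an aromatic carbon of the shared core gives an at least 7.1-fold lower number from compound 1 to compound 4 (0.85 log units; beyond the scatter), a change beyond the scatter. Compound 4 is the only one of the four compounds with a number rather than a limit, so this position is shown to respond to the group it carries, even though both groups are five-membered aromatic rings with 2 hetero atoms and have the same counts of hydrogen-bond donors and acceptors. The true size of the step remains unknown because the entry for compound 1 is a limit of the assay and not a number: the limit of > 10000 nM in this assay, at which 2 of the 4 values shown sit.

Going by these compounds alone, the single pair does not show which difference between the two rings accounts for the step, or whether the same exchange would lower the number on any other core. Also open, as far as these compounds go, is how a thiazole, a phenyl ring or an amine would read at the same aromatic carbon, and whether any of them would give a lower number than compound 4.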